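This account rests on a few compounds, and the source may have more. Where it says the series, first, only, none or still open, it means among the compounds named here.

This account follows three compounds through an ADME assay on HeLa cells (Homo sapiens) for cytotoxicity, read by ATP content, with a stated time of 3 days; a higher number here means that more compound is tolerated, a lower number that less compound is tolerated. Going by the values given here, compound 1, `CS(=O)(=O)CCCn1c(Cn2c(=O)n(C3CC3)c3ccncc32)nc2nc(Cl)ccc21`, is the first of the two measured ones. In this assay compound 1 reaches only the limit > 50000 nM, which is a boundary of the assay and not a number. Compound 2, `N#CCCCn1c(Cn2c(=O)n(-c3ncccn3)c3ccncc32)cc2cc(Cl)ccc21`, is the second measured compound and the starting point of the step examined here. In this assay compound 2 also gives only the limit > 50000 nM, again a boundary rather than a measured number. On the numbers shown, compound 2 therefore stands at the limit of > 50000 nM in this assay, at which 2 of the 2 values shown sit, with nothing to rank it against compound 1. Compound 3, `N#CCCCn1c(Cn2c(=O)n(-c3ccc(C(=O)O)cc3)c3ccncc32)cc2cc(Cl)ccc21`, differs from compound 2 in one place: 4-carboxyphenyl in place of pyrimidin-2-yl on an aromatic nitrogen. Among the compounds with values here, no measured step between compounds that differ in one place is available, and nothing in the two limits points in either direction. The step from compound 2 to compound 3 is expected to be a step that the limit leaves unreadable from compound 2 to compound 3, nothing beyond the usual scatter. Compound 3 is accordingly estimated at 60000 nM, within 25000 nM to 150000 nM, most probably reported once more only as a limit.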

Compound 3, half-maximal cytotoxic concentration: > 50000 nM
Compound 3: only a limit was reported (the forecaster's own chance of this, stated with the estimate: 85%); the middle value does not contradict the limit.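

In this assay compound 3 gives > 50000 nM, a limit of the assay and not a number. No step can be read between compound 2 and compound 3, which stand with compound 1 at one boundary: the limit of > 50000 nM in this assay, at which 3 of the 3 values shown sit. The compounds shown leave open whether 4-carboxyphenyl in place of pyrimidin-2-yl alters tolerance at all, and where any of the three would fall as an actual number.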